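The source may hold more compounds than are shown below. What is called first, only, known or untested is meant among the compounds shown, and "the series" means these compounds.

In a functional assay on SGC-7901 cells (Homo sapiens) for antiproliferative activity, read by MTT assay, with a stated time of 24 h (a higher number here means a weaker inhibitor, a lower number a stronger inhibitor), compound 1 `Cc1cccc(NNC(=O)c2ccccc2NS(=O)(=O)c2cnc(O)nc2O)c1` reports only a limit, > 20000 nM. Compound 2 `O=C(NNc1cccc(Cl)c1)c1ccccc1NS(=O)(=O)c1cnc(O)nc1O` gives 10800 nM. Compound 3 `CCCCOc1ccc(C(=O)NNC(=O)c2ccccc2NS(=O)(=O)c2cnc(O)nc2O)cc1` gives 6890 nM, a number within the scatter of that of compound 2. Compound 4 `O=C(NNC(=O)c1ccccc1NS(=O)(=O)c1cnc(O)nc1O)c1ccccc1Cl` carries 2-chlorophenyl in place of 4-butoxyphenyl on a carbonyl carbon. Among the compounds with values here, the only measured step, an at least 1.8-fold lower number from compound 1 to compound 2 (0.26 log units; that floor lies within the scatter), lies on an aromatic carbon and not on a carbonyl carbon, so it offers weak guidance here. No step beyond the scatter is therefore expected in this assay. The expected change is a 1.5-fold higher number from compound 3 to compound 4 (0.16 log units; within the scatter). For compound 4 the estimated value is 10000 nM, with an expected range from 4000 nM to 22000 nM.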

Compound 4, half-maximal inhibitory concentration: 2410 nM
For compound 4 the middle estimate is 4.1-fold (0.62 log units) above the measured one, and the stated range ends above it.
By their numbers in this assay, from the lowest: compound 4; then compounds 3 and 2 (each within the scatter of the next). At a limit, above all of these: compound 1.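

In this assay, unlike the step on an aromatic carbon, the change on this carbonyl carbon goes beyond the scatter, with 2-chlorophenyl in place of 4-butoxyphenyl giving a 2.9-fold lower number from compound 3 to compound 4 (0.46 log units; beyond the scatter). Placing (2-chlorophenyl)carbonyl on the amine nitrogen gives a 4.5-fold lower number from compound 2 to compound 4 (0.65 log units; beyond the scatter) and an at least 8.2-fold lower number from compound 1 to compound 4 (0.91 log units; beyond the scatter). The last of these is only a floor, as compound 1 reports a limit: the limit of > 20000 nM in this assay, at which 1 of the 4 values shown sits.

The compounds shown leave open whether the chlorine or the loss of the butoxy chain carries the step. They also leave open how a phenyl bearing an amine or a carboxylic acid would read on this carbonyl carbon.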